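A few compounds are considered here, and "the series" means these few. Any claim that something is new, unique, unknown or untested is made for them only; others in the source may bear on it.

Measured so far in a functional assay on A549 cells (Homo sapiens) for cytotoxicity, with a stated time of 48 h; a higher number here means a weaker inhibitor, a lower number a stronger inhibitor:
compound 1 `CCC(=O)Oc1ccc2oc(/C=C/[S+](C)[O-])cc(=O)c2c1` gives 2400 nM
compound 2 `C[S+]([O-])/C=C/c1cc(=O)c2cc(F)ccc2o1` gives 2100 nM
compound 3 `CCCC(=O)Oc1ccc2oc(/C=C/[S+](C)[O-])cc(=O)c2c1` gives 2200 nM

Compound 3 sits second highest of the three numbers, but the series is flat: its nearest neighbour is reached by a 1.0-fold higher number from compound 2 to compound 3 (0.02 log units; within the scatter), its furthest by a 1.1-fold lower number from compound 1 to compound 3 (0.04 log units; within the scatter), and the remaining pair is joined by a 1.1-fold lower number from compound 1 to compound 2 (0.06 log units; within the scatter). Within the data shown here, every step so far lies within the scatter, so none of the three compounds can be ordered against the others.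

Compound 4 `CC(C)Oc1ccc2oc(/C=C/[S+](C)[O-])cc(=O)c2c1` is not yet measured. The change from compound 3 is isopropyl in place of propylcarbonyl on an oxygen on an aromatic ring. Among the measured compounds shown here, no measured step makes this exact exchange. The steps that touch the same site are the swap of the whole (propylcarbonyl)oxy group for fluoro, a 1.0-fold higher number from compound 2 to compound 3 (0.02 log units; within the scatter), and the lengthening of the ester chain by methyl, a 1.1-fold lower number from compound 1 to compound 3 (0.04 log units; within the scatter); both were within the scatter. Replacing the ester with fluoro or lengthening it moved nothing, so removing the carbonyl while keeping a short chain on the aromatic oxygen is expected to move nothing either: the step of a 1.0-fold higher number from compound 3 to compound 4 (0.02 log units; within the scatter) is estimated to stay within the scatter, with no preferred direction.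

For compound 4 the expected value in this assay is 2300 nM, with a range of 1200 nM to 4600 nM.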

Compound 4, half-maximal inhibitory concentration: 1500 nM
Estimate against measurement, compound 4: 1.5-fold (0.19 log units) above, within the range that was stated.
By their numbers in this assay, from the lowest: compounds 4, 2, 3 and 1 (each within the scatter of the next).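

In this assay the oxygen on the aromatic ring accepts isopropyl in place of an acyl group without a step that can be read as a change: the exchange for propylcarbonyl gives a 1.5-fold lower number from compound 3 to compound 4 (0.17 log units; within the scatter) and the exchange for propanoyl gives a 1.6-fold lower number from compound 1 to compound 4 (0.20 log units; within the scatter), while the swap of fluoro for isopropoxy gives a 1.4-fold lower number from compound 2 to compound 4 (0.15 log units; within the scatter). The site therefore now holds two esters, fluoro and isopropoxy, and the carbonyl of the ester is shown not to be required for a number in this range, since all four compounds remain within the scatter of one another and cannot be ordered. No measurement in hand bears on the cause of this flatness.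

Still open, on these data alone, is whether any group at this site gives a step beyond the scatter, for example an amine, a carboxylic acid or a much longer chain on the aromatic oxygen. The rest of the shared core is the same in all four compounds, so the compounds shown say nothing about how far the number depends on it.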